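The compounds below may be only part of what the source reports. "The series", "measured", "known", "first", "only" and "open" are said of these compounds alone.

Measured in a functional assay on L1210 cells (Mus musculus) for antiproliferative activity, with a stated time of 48 h; on this read-out lower numbers stand for stronger inhibition and higher numbers for weaker inhibition:
- compound 1 `C=C(Br)C(=O)Nc1ccc(/C=C/C(=O)c2ccc(Cl)cc2)cc1`: 1100 nM
- compound 2 `Nc1ccc(/C=C/C(=O)c2ccc(F)cc2)cc1`: 123000 nM

Compound 2 holds the higher of the two numbers, and its gap to compound 1 lies well beyond the scatter, so compound 2 is the weaker inhibitor of the pair. The next compound to read is compound 3 `Nc1ccc(/C=C/C(=O)c2ccc(Cl)cc2)cc1`, not yet measured. It carries chloro in place of fluoro on an aromatic carbon. Within the data shown here, no measured pair isolates this change, so the expectation is anchored on compound 2 at 123000 nM. In this assay a small shift towards a lower number is expected, close to the scatter in size. The estimated step is a 2.1-fold lower number from compound 2 to compound 3 (0.31 log units; beyond the scatter). For compound 3 the expected value is 60000 nM, with an estimated range of 18000 nM to 150000 nM.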

Compound 3, half-maximal inhibitory concentration: 111000 nM
Compound 3: middle estimate off by 1.9-fold (0.27 log units), on the low side; measured number inside the range.
By their numbers in this assay, from the lowest: compound 1; then compounds 3 and 2 (each within the scatter of the next).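

In this assay, chloro in place of fluoro on the aromatic carbon para to a large group gives a 1.1-fold lower number from compound 2 to compound 3 (0.04 log units; within the scatter) and so leaves compound 2 and compound 3 indistinguishable; the choice between these two halogens does not register at this position when the nitrogen carries hydrogen. Among these compounds, compound 3 also gives the series its first single-place comparison at the nitrogen: hydrogen in place of (1-bromoethenyl)carbonyl corresponds to a 100-fold higher number from compound 1 to compound 3 (2.00 log units; beyond the scatter) and is the large step so far. No measured data explain either step.

From the compounds shown here alone, it remains open whether the bromine or the acyl part of the (1-bromoethenyl)carbonyl group carries that step, which an acetyl group on the nitrogen would help to separate. Also open, going by these compounds, is how methoxy or plain hydrogen would read at the halogen position.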